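Swapping a flexible ether amine for pyrrolidine

The source may report more compounds than this note shows. Statements on the series, on what has been measured and on what is new or still open speak of the compounds shown alone.

Compound 1, `CCOCC(COCC)Nc1nc(C)nc2c(-c3ccc(OC)cc3C)c(C)nn12`, gives 19.3 nM in an assay on cell membranes for displacement of a labelled ligand from corticotropin-releasing factor receptor 1 (Rattus norvegicus); a lower number here means a stronger inhibitor, a higher number a weaker inhibitor. Compound 2, `CCCCN(CC)c1nc(C)nc2c(-c3c(C)cc(OC)cc3C)c(C)nn12`, gives 4.22 nM in this assay.

Of the two measured compounds, compound 1 has the higher number; compound 2 lies a good way lower, beyond the usual scatter, so compound 2 is the stronger inhibitor of the pair. The two differ in more than one place, so no single change can be read off from their values.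

Compound 3, `COc1ccc(-c2c(C)nn3c(N4CCCC4)nc(C)nc23)c(C)c1`, has not yet been measured. It keeps the core and the aryl ring of compound 1 and changes one group: pyrrolidin-1-yl in place of (2-ethoxy-1-(ethoxymethyl)ethyl)amino on an aromatic carbon. The group that leaves is a flexible chain with a hydrogen-bond donor; the group that enters is a compact ring with none.

Nothing measured here shows what such a change does at this position, so the direction is open. The expected step from compound 1 to compound 3 is a 1.6-fold lower number from compound 1 to compound 3 (0.21 log units; within the scatter), a modest move toward a lower number, with a wide margin. Compound 3 is estimated at 12 nM in this assay, within 3 nM to 50 nM.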

Compound 3, half-maximal inhibitory concentration: 80.7 nM
Beside the measured number, compound 3's estimate is 6.7-fold (0.83 log units) below it; the measured number lies above the stated range.
By their numbers in this assay, from the lowest: compound 2; then compound 1; then compound 3.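

Going by these compounds alone, compound 1 and compound 3 differ in one place only, the aromatic carbon between two ring nitrogen atoms, so this pair gives the first reading of a single change. In this assay, putting pyrrolidin-1-yl in place of (2-ethoxy-1-(ethoxymethyl)ethyl)amino gives a 4.2-fold higher number from compound 1 to compound 3 (0.62 log units; beyond the scatter), which makes the compact ring the weaker choice and shows that the group at this position matters for the measured inhibition. No supporting measurement here explains the loss, so the result records its direction and size but not its origin.

The change removes the amine hydrogen, both ether oxygens and the open chain at once, and these compounds cannot separate those features from one another. A morpholin-4-yl ring or a dipropylamino group on the core and aryl ring of compound 1 would help to separate them, the first by restoring an oxygen within a ring, and the second by keeping open chains without an amine hydrogen.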